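The source may report more compounds than this note shows. Statements on the series, on what has been measured and on what is new or still open speak of the compounds shown alone.

In a functional assay on cells (Cancer cell lines, Homo sapiens) for cytotoxicity, read by sulforhodamine B assay, with a stated time of 48 h (a lower number here means a stronger inhibitor of growth, a higher number a weaker inhibitor of growth), compound 1 `NS(=O)(=O)c1ccc(-n2nc(-c3ccccc3)cc2-c2cc(O)ccc2O)cc1` gives 100000 nM; compound 2 `NS(=O)(=O)c1ccc(-n2nc(-c3ccc(Cl)cc3)cc2-c2cc(O)ccc2O)cc1` gives 39100 nM, the lowest number shown, though its gap to compound 3 stays within the scatter; compound 3 `CC(=O)NS(=O)(=O)c1ccc(-n2nc(-c3ccc(Cl)cc3)cc2-c2cc(O)ccc2O)cc1` gives 73700 nM. The step of a 2.6-fold lower number from compound 1 to compound 2 (0.41 log units; beyond the scatter) lies beyond the scatter, whereas the step of a 1.9-fold higher number from compound 2 to compound 3 (0.28 log units; within the scatter) does not. Compound 4 `NS(=O)(=O)c1ccc(-n2nc(-c3ccc(Cl)cc3)cc2C2=CC(=O)C=CC2=O)cc1` is not yet measured; its change from compound 2 is a group of 8 heavy atoms (6 carbon, 2 oxygen; one six-membered non-aromatic ring of carbon only) in place of a group of 8 heavy atoms (6 carbon, 2 oxygen; one six-membered aromatic ring of carbon only), on an aromatic carbon. For the measured compounds named here, neither measured step touches this part of the shared core, so no measured step bears on the change directly, and the steps in hand are modest at most. The expected step of a 2.6-fold lower number from compound 2 to compound 4 (0.42 log units; beyond the scatter) is therefore an estimate with wide bounds. Compound 4 is expected to give 15000 nM, with a range from 4000 nM to 60000 nM.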

Compound 4, concentration for total growth inhibition: 71100 nM
The estimate for compound 4 lay 4.7-fold (0.68 log units) below the measured number; measured number above the stated range.
By their numbers in this assay, from the lowest: compounds 2, 4, 3 and 1 (each within the scatter of the next, the first and the last beyond it).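

In this assay, putting the non-aromatic ring in place of 2,5-dihydroxyphenyl on the aromatic carbon next to the ring nitrogen gives a 1.8-fold higher number from compound 2 to compound 4 (0.26 log units; within the scatter) and so this first change at this position stays within the scatter. The entering group has 0 hydrogen-bond donors against 2 for the group that leaves, and this difference in count goes with no step beyond the scatter here. Nothing measured here accounts for this result.

From the compounds shown here alone, whether an amine or a carboxylic acid on this aromatic carbon would also stay within the scatter of compound 2 remains open. Going by these compounds, the effect of chloro in place of hydrogen is read only with 2,5-dihydroxyphenyl present, so its size with the entering ring is also open.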